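The compounds below may be only part of what the source reports. "The series", "measured", "known", "first", "only" and "open" are said of these compounds alone.

Measured so far:
compound 1, `CN1CCN(c2nc(Cl)nc3c2ncn3Cc2ccc(C(=O)Nc3ccccc3N)cc2)CC1`: 13.5%
compound 2, `Nc1ccccc1NC(=O)/C=C/c1ccc(Cn2cnc3c(Nc4cccc(Cl)c4)nc(Cl)nc32)cc1`: 7.11%

Both numbers come from a functional assay on NCI-H460 cells (Homo sapiens) for antiproliferative activity, read by CCK-8 assay, with a stated time of 72 h, tested at 2 uM; a higher number here means a stronger effect of the compound at the concentration tested, a lower number a weaker effect. In this assay compound 1 gives 13.5%, the higher of the two numbers, while compound 2 gives 7.11%; the gap between them lies within the scatter, so the two compounds read alike at this concentration and neither can be ranked above the other.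

Compound 3 is `Nc1ccccc1NC(=O)c1ccc(Cn2cnc3c(Nc4cccc(OC(F)(F)F)c4)nc(Cl)nc32)cc1`, not yet measured. It differs from compound 1 in one place: (3-(trifluoromethoxy)phenyl)amino in place of 4-methylpiperazin-1-yl on an aromatic carbon. Going by the values given here, no step between measured compounds isolates this change. Compound 2 carries neither the leaving nor the entering group exactly and differs from compound 3 elsewhere as well, so its value is only a loose reference. With both measured numbers low, a step of modest size is expected in this assay, if anything downward, and most likely no change beyond the scatter. For compound 3 the expected value is 10% (range 0% to 25%). That estimate implies a step of a number 3.5 percentage points lower from compound 1 to compound 3 (within the scatter), expected to stay within the scatter.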

Compound 3, a percentage reported as inhibition, at one concentration (the size of the read-out at that concentration, not a potency): 47.7%
Compound 3: middle estimate off by 37.7 percentage points, on the low side; measured number outside the range, above it.
By their numbers in this assay, from the lowest: compounds 2 and 1 (each within the scatter of the next); then compound 3.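

In this assay, going by these compounds alone, placing (3-(trifluoromethoxy)phenyl)amino instead of 4-methylpiperazin-1-yl on this aromatic carbon gives a number 34.2 percentage points higher from compound 1 to compound 3 (beyond the scatter), the only step so far that lies beyond the scatter. The group at this position can therefore change the read-out at the tested concentration substantially, with the rest of compound 1 left as it stands. No measured evidence bears on the reason for this step.

Within the data shown here, the single change swaps a saturated ring for an amino-linked aromatic ring carrying trifluoromethoxy, so the share of each feature in the step remains open. An unsubstituted phenylamino group, a 3-methoxyphenylamino group or a morpholin-4-yl group at this carbon would help separate those contributions, and a read-out at one concentration leaves potency itself undefined.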